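The source may hold more compounds than are shown below. What is called first, only, known or untested is meant among the compounds shown, and "the series" means these compounds.

Compound 3 `CCCCCCCCc1ccc(OCC(=O)Cn2nnnc2-c2ccccc2)cc1` sits second highest among the three numbers measured in an assay on microsomes from brain for inhibition of Fatty-acid amide hydrolase 1 (Rattus norvegicus), read by fluorescence and HPLC, with a stated time of 60 min (on this read-out lower numbers stand for stronger inhibition and higher numbers for weaker inhibition), with compound 3 giving 71 nM. Its nearest neighbour is compound 2 `CCCCCCCCc1ccc(OCC(=O)Cn2nnc(-c3ccc(C(=O)O)cc3)n2)cc1`, which gives 90 nM in this assay, a gap within the usual scatter. Furthest away is compound 1 `CCCCCCCCc1ccc(OCC(=O)Cn2nnc(-c3ccncc3)n2)cc1`, which gives 24 nM in this assay, a lower number beyond the scatter.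

Compound 4 `CCCCCCCCc1ccc(OCC(=O)Cn2nnnc2-c2ccncc2)cc1` differs from compound 3 in one place: pyridin-4-yl in place of phenyl on an aromatic carbon, on an aromatic carbon of a five-membered aromatic ring with four nitrogens, between two ring nitrogen atoms.

Within the data shown here, no measured step isolates this exact exchange. Among the measured compounds shown here, the only single-place step available, a 3.8-fold higher number from compound 1 to compound 2 (0.57 log units; beyond the scatter), swaps pyridin-4-yl for 4-carboxyphenyl on the other attachment and is modest. Compound 1 and compound 3 differ in two places at once, so their values cannot be split. Still, compound 1 carrying pyridin-4-yl gives 24 nM, which hints that a modestly lower number is expected for compound 4, a step of a 1.8-fold lower number from compound 3 to compound 4 (0.25 log units; within the scatter). Compound 4 is therefore estimated at 40 nM, within a range from 15 nM to 110 nM.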

Compound 4, half-maximal inhibitory concentration: 190 nM
Compound 4: middle estimate off by 4.8-fold (0.68 log units), on the low side; the whole stated range lies below it.
By their numbers in this assay, from the lowest: compound 1; then compounds 3 and 2 (each within the scatter of the next); then compound 4.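

Swapping phenyl for pyridin-4-yl on this aromatic carbon of the five-membered ring with four nitrogens gives a 2.7-fold higher number from compound 3 to compound 4 (0.43 log units; beyond the scatter) in this assay, which means weaker inhibition. Among these compounds, this is the first direct reading at this position, and it shows that a small change matters here: the ring keeps its 6 heavy atoms, yet exchanging one carbon for a nitrogen, which adds a hydrogen-bond acceptor, moves the number beyond the scatter. No measurement shown explains this rise.

As far as these compounds go, only these two groups can be compared at this position, so it remains open how a pyridin-3-yl group or a phenyl ring bearing an amine or a carboxylic acid would read there. Among the compounds shown here, it is also open whether the step would hold with a longer chain in place of the one these compounds share.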